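A fluoro for methoxy swap on compound 2

The compounds below may be only part of what the source reports. "The series", "measured", "known", "first", "only" and "open" are said of these compounds alone.

In a functional assay on MGC-803 cells (Homo sapiens) for inhibition, read by MTT assay, with a stated time of 48 h (a lower number here means a stronger inhibitor, a higher number a weaker inhibitor), compound 2 `C/C=C/C(=O)N(Cc1ccc(OC)c(OC)c1)c1cc(OC)c(OC)c(OC)c1` gives 20100 nM, the lower of the two numbers available. Compound 1 `COc1ccc(CNc2cc(OC)c(OC)c(OC)c2)cc1Cl` gives 46200 nM, a higher number, and the gap lies beyond the scatter. Compound 3 `COc1cc(NCc2ccc(Br)cc2)cc(OC)c1OC` returns only a limit, > 80000 nM. Compound 4 `C/C=C/C(=O)N(Cc1ccc(OC)c(F)c1)c1cc(OC)c(OC)c(OC)c1` differs from compound 2 in one place, with fluoro in place of methoxy on an aromatic carbon, ortho to a methoxy group and meta to a large group (fluoro in place of methoxy on an aromatic carbon). Among the compounds with values here, no measured pair tests this change directly. In this assay, the expected step, a 1.2-fold higher number from compound 2 to compound 4 (0.09 log units; within the scatter), is a slight move towards a weaker number that stays within the scatter. Compound 4 is estimated at 25000 nM, with an expected range of 9000 nM to 65000 nM.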

Compound 4, half-maximal inhibitory concentration: 1650 nM
Beside the measured number, compound 4's estimate is 15-fold (1.18 log units) above it; measured number outside the range, below it.
By their numbers in this assay, from the lowest: compound 4; then compound 2; then compound 1. At a limit, above all of these: compound 3.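

Swapping methoxy for fluoro on this aromatic carbon, ortho to a methoxy group and meta to a large group, gives a 12-fold lower number from compound 2 to compound 4 (1.09 log units; beyond the scatter) in this assay. This first direct test shows that the position is far from indifferent to what it carries, and that one small swap here can move the number well beyond the scatter. No measurement shown here bears on the cause of this step.

Going by these compounds, it remains open whether the step comes from fluoro itself or from the loss of methoxy. Hydrogen, chloro or hydroxyl on the same carbon would separate these two readings.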